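A Ring Replaces Ethyl on the Chain Carbon

The source may hold more compounds than are shown below. What is called first, only, known or untested is meant among the compounds shown, and "the series" means these compounds.

Going by the values given here, in a functional assay on SW1573 cells (Homo sapiens) for antiproliferative activity, read by sulforhodamine B assay, with a stated time of 48 h (a higher number here means a weaker inhibitor of growth, a lower number a stronger inhibitor of growth), compound 2 `CCC(C#CC(=O)OC)O/C=C/C(=O)OC` gives 540 nM and holds the lower of the two numbers so far. Compound 1 `CCCCCC(C#CC(=O)OC)O/C=C/C(=O)OC`, whose chain runs longer by propyl, gives 1700 nM in the same test. Compound 3 `COC(=O)C#CC(O/C=C/C(=O)OC)C1CCCCC1` brings a new change (cyclohexyl in place of ethyl on a saturated chain carbon bound to an oxygen on an unsaturated carbon and a triple-bonded carbon): cyclohexyl in place of ethyl on a saturated chain carbon bound to an oxygen on an unsaturated carbon and a triple-bonded carbon. Among the compounds with values here, only one measured step bears on this, a 3.1-fold lower number from compound 1 to compound 2 (0.50 log units; beyond the scatter), where the smaller group went with the lower number. That is a single pair of open chains, and no ring has been measured here, so the guide is weak. A modest move towards a higher number is expected, an estimated 2.2-fold higher number from compound 2 to compound 3 (0.35 log units; beyond the scatter) in this assay. The estimate for compound 3 is 1200 nM with an expected range from 450 nM to 3200 nM in this test.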

Compound 3, concentration for 50% growth inhibition: 2100 nM
Compound 3: middle estimate off by 1.8-fold (0.24 log units), on the low side; the measured number falls inside the stated range.
By their numbers in this assay, from the lowest: compound 2; then compounds 1 and 3 (each within the scatter of the next).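

In this assay, the first ring at this position, cyclohexyl in place of ethyl on a saturated chain carbon bound to an oxygen on an unsaturated carbon and a triple-bonded carbon, gives a 3.9-fold higher number from compound 2 to compound 3 (0.59 log units; beyond the scatter) and so does not keep the lower number held by ethyl. Set against the open chain of compound 1, the same ring gives a 1.2-fold higher number from compound 1 to compound 3 (0.09 log units; within the scatter) and cannot be told apart from pentyl in this test, so among these three compounds only ethyl stands apart, and the ring itself brings no separate gain or loss. No measurement on hand explains these differences.

Whether methyl at this position would fall below ethyl remains open, since ethyl is the smallest group shown. Also open, from the compounds shown here alone, is how a flat phenyl ring or a chain ending in an amine would compare with cyclohexyl.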